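A Diethylamino Chain Replaces a Branched One

The compounds below may be only part of what the source reports. "The series", "measured", "known", "first", "only" and "open" are said of these compounds alone.

In a functional assay on DU-145 cells (Homo sapiens) for antiproliferative activity, read by WST assay, with a stated time of 3 days (a lower number here means a stronger inhibitor, a higher number a weaker inhibitor), compound 1 (`CCCOc1c(-c2cc(OC)c(OC)c(OC)c2)oc2ccccc2c1=O`), with a propyl chain on the oxygen, gives 2800 nM. Compound 2 (`CCCCCCCOc1c(-c2cc(OC)c(OC)c(OC)c2)oc2ccccc2c1=O`), with a heptyl chain, gives > 50000 nM, which is a limit and not a number. Compound 3 (`CCCC(C)Oc1c(-c2cc(OC)c(OC)c(OC)c2)oc2ccccc2c1=O`), with a 1-methylbutyl chain, gives > 50000 nM, which is also a limit. Compound 3 therefore stands at the limit of > 50000 nM in this assay, at which 2 of the 3 values shown sit, with no exact value of its own.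

Compound 4 (`CCN(CC)CCCOc1c(-c2cc(OC)c(OC)c(OC)c2)oc2ccccc2c1=O`) carries 3-(diethylamino)propyl in place of 1-methylbutyl on an oxygen on an aromatic ring. Two large measured steps bear on this change: an at least 17-fold higher number from compound 1 to compound 2 (1.25 log units; beyond the scatter) and an at least 17-fold higher number from compound 1 to compound 3 (1.25 log units; beyond the scatter). The new chain is a substituted propyl, so compound 1 is the closest measured guide, although the first of those steps warns that extending its chain can cost much activity.

In this assay, the expected change is an at least 7.1-fold lower number from compound 3 to compound 4 (0.85 log units; beyond the scatter), a move toward stronger inhibition. For compound 4, the estimate is 7000 nM, with an expected range of 1200 nM to 45000 nM.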

Compound 4, half-maximal inhibitory concentration: > 50000 nM
Compound 4 ended at the assay's limit; the forecaster's own chance of this, stated with the estimate: 25%; at least 7.1-fold (0.85 log units) between middle value and limit.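

In this assay, putting diethylamino on the end of the propyl chain does not keep the activity of compound 1: the change gives an at least 17-fold higher number from compound 1 to compound 4 (1.25 log units; beyond the scatter). Steps linking compound 2, compound 3 and compound 4 join one limit to another and cannot be read, so these three chains cannot be ranked. Among the chains shown on this oxygen, only the propyl of compound 1 gives an exact value, and the amine-bearing chain joins the heptyl and 1-methylbutyl chains at the limit: the limit of > 50000 nM in this assay, at which 3 of the 4 values shown sit.

The compounds shown leave open whether a shorter chain such as ethyl, or a propyl chain ending in a hydroxyl group or a dimethylamino group, would match or improve on compound 1 at 2800 nM. They also cannot separate the effect of the diethylamino group itself from that of the overall length of the chain.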